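Reshaping the amide-bound ring system of compound 1

The compounds below may be only part of what the source reports. "The series", "measured", "known", "first", "only" and "open" are said of these compounds alone.

Three compounds, all built around a benzylamide carrying an aryl sulfone or sulfonamide, have been tested in an assay for inhibition of Nicotinamide phosphoribosyltransferase (Homo sapiens), read by mass spectrometry, with stated times of 15 min and 30 min; a higher number here means a weaker inhibitor, a lower number a stronger inhibitor. Compound 1 `O=C(NCc1ccc(S(=O)(=O)c2ccccc2)cc1)c1nc2cnccc2[nH]1` gives 7100 nM, the highest of the three numbers. Compound 2 `O=C(NCc1ccc(S(=O)(=O)c2ccccc2C(F)(F)F)cc1)c1cc2cnccc2[nH]1` gives 24 nM in this assay, and compound 3 `O=C(NCc1ccc(S(=O)(=O)N2CCCCC2)cc1)c1cc2cnccc2o1` gives 140 nM; both gaps to compound 1 are beyond the scatter. Compound 4 `O=C(NCc1ccc(S(=O)(=O)c2ccccc2)cc1)c1cn2ccnc2cn1` keeps every atom of compound 1 but joins them differently: a group of 9 heavy atoms (6 carbon, 3 nitrogen; one five-membered aromatic ring with 2 hetero atoms, one six-membered aromatic ring with 2 hetero atoms) in place of a group of 9 heavy atoms (6 carbon, 3 nitrogen; one five-membered aromatic ring with 2 hetero atoms, one six-membered aromatic ring with 1 hetero atom), on a carbonyl carbon. Among the compounds with values here, with no measured pair showing this kind of swap, its effect cannot be read from the data. Compound 4 is expected to land near compound 1, with a step of a 2.0-fold lower number from compound 1 to compound 4 (0.31 log units; beyond the scatter) that may fall within the scatter. The estimate for compound 4 is 3500 nM, in the range 600 nM to 15000 nM.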

Compound 4, half-maximal inhibitory concentration: 150 nM
Beside the measured number, compound 4's estimate is 23-fold (1.37 log units) above it; measured number below the stated range.
By their numbers in this assay, from the lowest: compound 2; then compounds 3 and 4 (each within the scatter of the next); then compound 1.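

Joining the same atoms differently in the ring group on the carbonyl carbon gives a 47-fold lower number from compound 1 to compound 4 (1.68 log units; beyond the scatter) in this assay, so this position responds to how the atoms are connected, not only to which atoms are present. The entering group has 0 hydrogen-bond donors and the leaving group has 1, so a donor in this group is not needed to reach the number of compound 4 . Nothing measured here gives a reason for the gain. On these data alone, whether the gain carries over when trifluoromethyl sits on the sulfone's phenyl ring remains open. So does the effect of an amine or a methyl group on the entering ring group.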